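Swapping the Pendant Ring: Does Cytotoxicity Change?

The source may hold more compounds than are shown below. What is called first, only, known or untested is meant among the compounds shown, and "the series" means these compounds.

Compound 1 `Cc1ccc(-c2ccc3[nH]c(=O)nc(-c4ccccc4)c3c2)cn1`: > 50000 nM, a limit of the assay.
Compound 2 `O=c1nc(-c2ccccc2)c2cc(-c3ccc(N4CCCC4)nc3)ccc2[nH]1`: > 50000 nM, a limit of the assay.
Compound 3 `O=c1nc(-c2ccccc2)c2cc(-c3ccccc3F)ccc2[nH]1`: 50000 nM.

In an ADME assay on THP-1 cells (Homo sapiens) for cytotoxicity, read by MTT assay, with a stated time of 72 h (on this read-out lower numbers stand for an effect already at smaller amounts and higher numbers for an effect only at larger amounts of compound), compound 1 is known only through a limit, sitting at the limit of > 50000 nM in this assay, at which 2 of the 3 values shown sit. The step that the two limits leave unreadable from compound 1 to compound 2 is therefore unreadable, and the step of a number no higher from compound 1 to compound 3 (the limit leaves the size open) shows a number no higher, its size left open.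

Compound 4 `O=c1nc(-c2ccccc2)c2cc(-c3ccc(F)cc3)ccc2[nH]1` differs from compound 1 by 4-fluorophenyl in place of 6-methylpyridin-3-yl on an aromatic carbon. The closest measured precedent is the step to compound 3, which also exchanges this pendant ring for a fluorophenyl and stayed at or near the limit. No step beyond the scatter is expected, so the estimated change is a number no higher from compound 1 to compound 4 (the limit leaves the size open). Compound 4 is expected at 50000 nM, between 25000 nM and 100000 nM.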

Compound 4, half-maximal effective concentration: > 50000 nM
Compound 4: only a limit was reported; the forecaster's own chance of this, stated with the estimate: 65%; the middle value sits exactly at the limit.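

Compound 4 shows that a pendant ring of carbon only, carrying no ring nitrogen, can also sit at the limit in this assay: the limit of > 50000 nM in this assay, at which 3 of the 4 values shown sit.
Placing 4-fluorophenyl in place of 2-fluorophenyl gives a number no lower from compound 3 to compound 4 (the limit leaves the size open). The step between compound 1 and compound 4 cannot be read.

The compounds shown leave open how far the cytotoxicity read-out can move through changes at this position. A carboxylic acid or a primary amine on the pendant ring might give a value clearly lower than these, or might not.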